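Swapping the Aryl Group on the Saturated Ring Carbon

The source may hold more compounds than are shown below. What is called first, only, known or untested is meant among the compounds shown, and "the series" means these compounds.

Measured compounds:
Compound 1 `COc1cc(/C=C/C(=O)C2=C(/C=C/c3ccc(O)c(OC)c3)NC(=O)NC2c2ccc(O)cc2)ccc1O`: 72%
Compound 2 `COc1cc(/C=C/C(=O)C2=C(/C=C/c3ccc(O)c(OC)c3)NC(=O)NC2c2cccc([N+](=O)[O-])c2)ccc1O`: 19.9%

In a functional assay, with a stated time of 20 min, tested at 10 uM (on this read-out higher numbers stand for a stronger effect at the one concentration tested and lower numbers for a weaker effect), compound 2 gives the lower of the two numbers; compound 1 sits a number 52.1 percentage points lower from compound 1 to compound 2 (beyond the scatter), a step that came with 3-nitrophenyl in place of 4-hydroxyphenyl on a saturated ring carbon. Compound 3 `COc1cc(/C=C/C(=O)C2=C(/C=C/c3ccc(O)c(OC)c3)NC(=O)NC2c2ccccc2Cl)ccc1O` differs from compound 2 at the same carbon: 2-chlorophenyl in place of 3-nitrophenyl on a saturated ring carbon. Going by the values given here, only one measured step bears on this spot, a number 52.1 percentage points lower from compound 1 to compound 2 (beyond the scatter), and it shows that the group on this saturated ring carbon can shift the read-out strongly. Among the compounds with values here, no measured pair compares 3-nitrophenyl with 2-chlorophenyl, so the direction is open; since compound 1 is the only compound with a high number and compound 3 does not restore its 4-hydroxyphenyl, the expectation for compound 3 is a modest change, a number 15.1 percentage points higher from compound 2 to compound 3 (beyond the scatter), to an estimated 35% within 10% to 65%.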

Compound 3, a percentage reported as activity, at one concentration (the size of the read-out at that concentration, not a potency): 23%
Estimate against measurement, compound 3: 12 percentage points above; the range from low to high includes it.
By their numbers in this assay, from the lowest: compounds 2 and 3 (each within the scatter of the next); then compound 1.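

In this assay the change from 3-nitrophenyl to 2-chlorophenyl on the saturated ring carbon gives a number 3.1 percentage points higher from compound 2 to compound 3 (within the scatter) and so leaves these two groups indistinguishable on this read-out. The comparison with the 4-hydroxyphenyl compound gives a number 49 percentage points lower from compound 1 to compound 3 (beyond the scatter) and shows that a large drop is not unique to 3-nitrophenyl, since two different replacements now come with one. Among these three compounds only compound 1 gives a high number, but three aryl groups are too few to show which feature of 4-hydroxyphenyl matters, and no supporting measurement explains the difference.

From the compounds shown here alone, whether the hydroxyl group itself is what counts remains open, and plain phenyl or 4-methoxyphenyl at this carbon would bear on that. Also open, going by these compounds, is how 4-aminophenyl would read, and whether the identity of a ring substituent matters more than where it sits.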